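This account rests on a few compounds, and the source may have more. Where it says the series, first, only, none or still open, it means among the compounds named here.

In a functional assay on A549 cells (Homo sapiens) for antiproliferative activity, read by MTT assay (on this read-out lower numbers stand for stronger inhibition and higher numbers for weaker inhibition), compound 1 (`Cc1nn2c(-c3nc4cc(Cl)c(F)cc4[nH]3)c(-c3ccc(F)cc3)nc2s1`) gives > 30000 nM, which is a limit of the assay. For the measured compounds named here, compound 2 (`Cc1nn2c(-c3nc4cc(Cl)ccc4[nH]3)c(-c3ccc(F)cc3)nc2s1`) gives 10200 nM, the only true number so far. Compound 3 (`Cc1nn2c(-c3nc4cc(Cl)c(Cl)cc4[nH]3)c(-c3ccc(F)cc3)nc2s1`) differs from compound 2 by chloro in place of hydrogen on an aromatic carbon, a chloro in place of hydrogen on an aromatic carbon. Going by the values given here, the one measured step bearing on this is an at least 2.9-fold lower number from compound 1 to compound 2 (0.46 log units; beyond the scatter), which replaced fluoro with hydrogen and rests on (the limit of > 30000 nM in this assay, at which 1 of the 2 values shown sits). Putting a halogen back on compound 2 should therefore weaken inhibition in this assay, and the expected change is a 2.0-fold higher number from compound 2 to compound 3 (0.29 log units; within the scatter). For compound 3, the estimated value is 20000 nM, within an expected range of 9000 nM to 45000 nM.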

Compound 3, half-maximal inhibitory concentration: > 30000 nM
Compound 3 ended at the assay's limit; the forecaster's own chance of this, stated with the estimate: 45%; middle value at least 1.5-fold (0.17 log units) from the limit.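

Adding chloro on this aromatic carbon, ortho to a chloro group, gives an at least 2.9-fold higher number from compound 2 to compound 3 (0.46 log units; beyond the scatter) in this assay. Compound 1 and compound 3 both stand at a limit, so a halogen at this place now goes with weaker inhibition than hydrogen twice, with chloro as well as with fluoro: the limit of > 30000 nM in this assay, at which 2 of the 3 values shown sit.

The step from compound 1 to compound 3 cannot be read, so fluoro and chloro remain unranked at this place. From the compounds shown here alone, whether a methoxy group or an amine here would keep or improve on the inhibition of compound 2 remains open.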